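The compounds below may be only part of what the source reports. "The series", "measured", "known", "first", "only" and "open" are said of these compounds alone.

Measured compounds in the series:

Compound 1 `Cc1ccc(NC(=O)c2cccc(C(F)(F)F)c2)cc1N1Cc2cnc(Nc3ccc(C)c(C(F)(F)F)c3)nc2N(C)C1=O`: in a functional assay on K562 cells (Homo sapiens) for antiproliferative activity, read by CellTiter-Glo and CCK-8 assay, with a stated time of 72 h (on this read-out lower numbers stand for stronger inhibition of growth and higher numbers for weaker inhibition of growth), compound 1 gives 29 nM
Compound 2 `CNc1nc(Nc2ccc(C)c([N+](=O)[O-])c2)ncc1C(=O)Nc1cc(NC(=O)c2cccc(OC)c2)ccc1C`: in this assay compound 2 gives 480 nM
Compound 3 `CNc1nc(Nc2ccc(C)c(N)c2)ncc1C(=O)Nc1cc(NC(=O)c2cccc(OC)c2)ccc1C`: in this assay compound 3 gives 330 nM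

Compound 3 stands second highest of the three numbers. Its nearest neighbour is compound 2, and the step of a 1.5-fold lower number from compound 2 to compound 3 (0.16 log units; within the scatter) lies within the scatter, so the two are not ordered by these data. Compound 1, at 29 nM, sits far lower, with a gap to compound 3 that is beyond the scatter; compound 1 also differs from compound 3 in several places at once, so no single change is tied to that gap.

The step to compound 4 `CNc1nc(Nc2ccc(C)c(N)c2)ncc1C(=O)Nc1cc(NC(=O)c2cc(OC)c(OC)c(OC)c2)ccc1C` is 3,4,5-trimethoxyphenyl in place of 3-methoxyphenyl on a carbonyl carbon. For the measured compounds named here, none of the measured steps touches this part of the molecule: the only single-point step known, from nitro to amino on the aromatic carbon, leaves the benzamide aryl untouched and was itself within the scatter. Going by the values given here, there is therefore no measured precedent for the methoxy count on this ring, and the expectation defaults to no step beyond the scatter, with the range widened for the lack of any direct comparison. The expected step is no change at the digits printed from compound 3 to compound 4 (within the scatter). Compound 4 is estimated at 330 nM, in the range 110 nM to 1000 nM.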

Compound 4, concentration for 50% growth inhibition: 250 nM
Estimate against measurement, compound 4: 1.3-fold (0.12 log units) above; the measured number falls inside the stated range.
By their numbers in this assay, from the lowest: compound 1; then compounds 4, 3 and 2 (each within the scatter of the next).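

In this assay, for the compounds shown here, the first measured change at the aryl on this carbonyl carbon, 3,4,5-trimethoxyphenyl in place of 3-methoxyphenyl, gives a 1.3-fold lower number from compound 3 to compound 4 (0.12 log units; within the scatter), so compound 3 and compound 4 are not ordered by these data. This place therefore accepts a group of 12 heavy atoms and 3 hydrogen-bond acceptors in place of one of 8 heavy atoms and 1 hydrogen-bond acceptor with no step beyond the scatter, which the earlier nitro-to-amino step, made elsewhere on the molecule, could not show. No measurement in hand offers an explanation for this result.

Going by these compounds, it remains open whether a different kind of group on this carbonyl carbon, such as a carboxylic acid, a dimethylamino group or a longer alkyl chain, would produce a step beyond the scatter. Compound 1, with 29 nM, differs from compound 4 in several places at once, so the contribution of this aryl to its value cannot be read from the compounds shown.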